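Working notes: from compound 3 to compound 4

The compounds below may be only part of what the source reports. "The series", "measured", "known", "first", "only" and "open" are said of these compounds alone.

Measured in a functional assay for inhibition, with Homo sapiens as the target; on this read-out lower numbers stand for tighter binding and higher numbers for weaker binding:
- compound 1 `O=C(O)CC/C=C\CC1COC(c2ccc3ccccc3c2)OC1c1cccnc1`: 1780 nM
- compound 2 `CSc1ccc(OC(C)(C)C2OCC(C/C=C\CCC(=O)O)C(c3cccnc3)O2)c([N+](=O)[O-])c1`: 4.47 nM
- compound 3 `CC(C)(Oc1ccccc1F)C1OCC(C/C=C\CCC(=O)O)C(c2cccnc2)O1`: 166 nM

Of these three numbers, the value for compound 3 is the second highest. It lies below the value for compound 1 and above the value for compound 2, and both gaps are beyond the scatter.

The next compound is compound 4 `COc1ccc(OC(C)(C)C2OCC(C/C=C\CCC(=O)O)C(c3cccnc3)O2)c([N+](=O)[O-])c1`, not yet measured in this assay. It carries 4-methoxy-2-nitrophenyl in place of 2-fluorophenyl on an oxygen on a saturated carbon.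

Going by the values given here, one measured step bears on this change: a 37-fold higher number from compound 2 to compound 3 (1.57 log units; beyond the scatter). That step is large and beyond the scatter. It ends in the 2-fluorophenyl compound and changes the group at the same place, so it is read here in reverse. Among the compounds with values here, no measured step matches the present change exactly, and this single step is the only guide to its size, so the range is kept wide.

Within the data shown here, a large step to a lower number is expected, somewhat smaller than the one seen with compound 2. The expected step is a 24-fold lower number from compound 3 to compound 4 (1.38 log units; beyond the scatter).

For compound 4 the estimate is 7 nM, with an expected range from 2.5 nM to 25 nM.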

Compound 4, dissociation constant: 6.17 nM
The estimate for compound 4 lay 1.1-fold (0.05 log units) above the measured number; measured number inside the range.
By their numbers in this assay, from the lowest: compounds 2 and 4 (each within the scatter of the next); then compound 3; then compound 1.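

In this assay, 4-methoxy-2-nitrophenyl in place of 2-fluorophenyl on an oxygen on a saturated carbon gives a 27-fold lower number from compound 3 to compound 4 (1.43 log units; beyond the scatter), so the large gap first seen with compound 2 also appears with a second substituted phenyl group at this place. Methoxy in place of methylsulfanyl on an aromatic carbon gives a 1.4-fold higher number from compound 2 to compound 4 (0.14 log units; within the scatter), which is within the scatter, so the gap to compound 3 does not depend on methylsulfanyl and this assay separates compound 2 and compound 4 from neither each other nor their shared low range. No measurement of any property of these groups accompanies the numbers, and the step therefore remains a description of the change alone. Between compound 3 and compound 4 the fluorine, the nitro group and the methoxy group all change together, so the share of the step belonging to each stays open. As far as these compounds go, how an amine or a nitrile would read in place of the methoxy, or a trifluoromethyl group in place of the nitro group, also stays open.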